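Replacing the Dimethoxyphenyl Group of Compound 2

A few compounds are considered here, and "the series" means these few. Any claim that something is new, unique, unknown or untested is made for them only; others in the source may bear on it.

In a functional assay on HCT-116 cells (Homo sapiens) for antiproliferative activity, read by MTT assay, with a stated time of 48 h (on this read-out lower numbers stand for stronger inhibition and higher numbers for weaker inhibition), compound 1 `COc1ccc(OC)c(CN2CCc3nc(N4CCN(c5ncccn5)CC4)ncc3C2)c1` gives 43200 nM and compound 2 `COc1ccc(OC)c(C(=O)N2CCc3nc(N4CCN(c5ncccn5)CC4)ncc3C2)c1` gives 34600 nM so these two numbers sit within the usual scatter of each other, and compound 2 stands level with compound 1. Compound 3 `O=C(c1ccc(F)cc1)N1CCc2nc(N3CCN(c4ncccn4)CC3)ncc2C1` keeps the shared core of compound 2 but carries 4-fluorophenyl in place of 2,5-dimethoxyphenyl on a carbonyl carbon. Among the measured compounds shown here, no measured pair shows this kind of change, so in this assay no step beyond the scatter is expected. The estimated 1.4-fold lower number from compound 2 to compound 3 (0.14 log units; within the scatter) is accordingly small. Compound 3 is expected at 25000 nM (range 9000 nM to 60000 nM).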

Compound 3, half-maximal inhibitory concentration: 67900 nM
Compound 3: the middle estimate sits 2.7-fold (0.43 log units) below what was measured, outside the stated range (above it).
By their numbers in this assay, from the lowest: compounds 2, 1 and 3 (each within the scatter of the next).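

In this assay, 4-fluorophenyl in place of 2,5-dimethoxyphenyl on a carbonyl carbon gives a 2.0-fold higher number from compound 2 to compound 3 (0.29 log units; within the scatter) and (4-fluorophenyl)carbonyl in place of 2,5-dimethoxybenzyl on an amine nitrogen in a ring gives a 1.6-fold higher number from compound 1 to compound 3 (0.20 log units; within the scatter) so neither change separates the compounds. Even with a different aromatic group on the carbonyl carbon, all three compounds stand level, and this position has not yet shown a clear response to change. Nothing available explains these numbers. Going by these compounds, whether an amine, a carboxylic acid or a longer chain in place of the aromatic group would give a step beyond the scatter remains open.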